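The source may hold more compounds than are shown below. What is called first, only, known or untested is meant among the compounds shown, and "the series" means these compounds.

Compound 1 `COc1cc(Nc2ncc(C(F)(F)F)c(N3Cc4cccc(N(C)S(C)(=O)=O)c4C3)n2)c(OC)cc1Cl`: 7300 nM
Compound 2 `CN(c1cccc2c1CN(c1nc(Nc3cc(C(F)(F)F)cc(C(F)(F)F)c3)ncc1C(F)(F)F)C2)S(C)(=O)=O`: > 30000 nM

Both compounds were tested in a functional assay on A549 cells (Homo sapiens) for antiproliferative activity, read by spectrophotometry, with a stated time of 2 days; a higher number here means a weaker inhibitor of growth, a lower number a stronger inhibitor of growth. Compound 1 gives a true measured number, 7300 nM. Compound 2 gives > 30000 nM, which is a limit of the assay and not a number. On these data alone, the evidence so far therefore includes (the limit of > 30000 nM in this assay, at which 1 of the 2 values shown sits), and the real position of compound 2 is unknown.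

Compound 3 `COc1cc(Nc2ncc(C(F)(F)F)c(N3Cc4cccc(N(C)S(C)(=O)=O)c4C3)n2)cc(C(F)(F)F)c1` differs from compound 2 in one place: methoxy in place of trifluoromethyl on an aromatic carbon, meta to a trifluoromethyl group (methoxy in place of trifluoromethyl on an aromatic carbon). Within the data shown here, no measured pair isolates this change, so any forecast in this assay rests on thin ground. Compound 1, which also carries methoxy, gives 7300 nM. On that basis alone, a modest step toward stronger inhibition of growth is expected, though a result that again reaches the limit remains possible.

This estimate means an expected step of an at least 2.5-fold lower number from compound 2 to compound 3 (0.39 log units; beyond the scatter). For compound 3 the estimated value is 12000 nM, with an expected range from 4000 nM to 30000 nM.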

Compound 3, concentration for 50% growth inhibition: > 30000 nM
Compound 3 gave a limit, no number (the forecaster's own chance of this, stated with the estimate: 25%); at least 2.5-fold (0.39 log units) between middle value and limit.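

In this assay compound 3 gives > 30000 nM, which is a limit of the assay and not a number, so methoxy in place of trifluoromethyl at this place does not on its own give a measurable value. Among these compounds, the one readable comparison is an at least 4.1-fold higher number from compound 1 to compound 3 (0.61 log units; beyond the scatter), which comes with 3-methoxy-5-(trifluoromethyl)phenyl in place of 4-chloro-2,5-dimethoxyphenyl on the nitrogen, so one methoxy on this ring does not match what the full 4-chloro-2,5-dimethoxyphenyl group gives. The step between the two compounds that carry limits cannot be read, and the shared ceiling is all they have in common here: the limit of > 30000 nM in this assay, at which 2 of the 3 values shown sit.

On these data alone, it remains open whether methoxy improves on trifluoromethyl at all, and which part of 4-chloro-2,5-dimethoxyphenyl matters, the chlorine or either methoxy, as compound 1 and compound 3 differ in several atoms of that ring at once. As far as these compounds go, it is also open how an amine or a carboxylic acid at this place on the ring would read in this assay.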